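The source may hold more compounds than are shown below. What is called first, only, known or untested is meant among the compounds shown, and "the series" means these compounds.

Measured compounds:
compound 1, `Cc1ccc(S(=O)(=O)N2C=CNC(=O)[C@H]2CC(=O)N[C@H](C)c2ccccc2)cc1`, with 836 nM in an in vitro functional assay on cells for antagonist activity at B1 bradykinin receptor (Homo sapiens), read by luminescence and calcium flux, with a stated time of 2 h; on this read-out higher numbers stand for weaker inhibition and lower numbers for stronger inhibition
compound 2, `Cc1ccc(S(=O)(=O)N2C=CNC(=O)[C@H]2CC(=O)NC2CCCCC2C)cc1`, with 25.9 nM in this assay

On these two numbers compound 2 stands lowest, and its nearest neighbour is compound 1 with a 32-fold lower number from compound 1 to compound 2 (1.51 log units; beyond the scatter). Compound 3, `Cc1ccc(S(=O)(=O)N2C=CNC(=O)[C@H]2CC(=O)N[C@H]2CCN(C)CC2(C)C)cc1`, carries a group of 9 heavy atoms (8 carbon, 1 nitrogen; one six-membered non-aromatic ring with 1 hetero atom) in place of a group of 7 heavy atoms (7 carbon; one six-membered non-aromatic ring of carbon only), on an amide-type nitrogen. Among the compounds with values here, the only measured step, the one from compound 1 to compound 2, exchanges a ring on the same amide-type nitrogen, but it swaps an aromatic ring for a saturated one, while compound 3 keeps a saturated six-membered ring and brings in a nitrogen. That step offers no direct guide, so the expected change is modest: compound 3 is estimated to give a 3.1-fold higher number from compound 2 to compound 3 (0.49 log units; beyond the scatter), meaning 80 nM with a range from 15 nM to 500 nM.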

Compound 3, half-maximal inhibitory concentration: 0.42 nM
The estimate for compound 3 lay 190-fold (2.28 log units) above the measured number, outside the stated range (below it).
By their numbers in this assay, from the lowest: compound 3; then compound 2; then compound 1.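

At this amide-type nitrogen, a saturated carbon ring is not the best group seen: the six-membered ring with a hetero atom gives a 62-fold lower number from compound 2 to compound 3 (1.79 log units; beyond the scatter) in this assay. Measured against the 1-phenylethyl group, the same ring gives a 2000-fold lower number from compound 1 to compound 3 (3.30 log units; beyond the scatter) on an unchanged core, so this one position alone can move the number very far. Nothing measured here explains the gain. Going by these compounds, the entering group differs from 2-methylcyclohexyl in more than one feature, so the separate shares of its ring nitrogen and its methyl groups stay open. An unsubstituted piperidine ring on this nitrogen would help to separate them.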